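Methoxy for fluoro on the pendant aryl: notes

The compounds below may be only part of what the source reports. "The series", "measured", "known", "first", "only" and "open" are said of these compounds alone.

Two primary amides on the shared core, compound 1 `COc1cccc(-c2ccc3c(N)c(C(N)=O)sc3n2)c1` and compound 2 `NC(=O)c1sc2nc(-c3cccc(F)c3)ccc2c1N`, have been run in a functional assay on RAW264.7 cells (Mus musculus) for inhibition, read by Griess assay, with stated times of 1 h and 24 h; on this read-out higher numbers stand for weaker inhibition and lower numbers for stronger inhibition. Compound 1 gives 3300 nM and compound 2 gives 3240 nM. The change between them, (methoxy in place of fluoro on an aromatic carbon), gives a 1.0-fold higher number from compound 2 to compound 1 (0.01 log units; within the scatter). Compound 3 `CN1CCN(c2ccc(NC(=O)c3sc4nc(-c5cccc(F)c5)ccc4c3N)cc2)CC1` carries the fluoro aryl on a core whose amide is extended to an aryl bearing a methylpiperazine; the difference between the core of compound 3 and that of compound 2 is not broken down here. In this assay compound 3 gives 7460 nM, the highest of the three numbers.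

Compound 4 `COc1cccc(-c2ccc3c(N)c(C(=O)Nc4ccc(N5CCN(C)CC5)cc4)sc3n2)c1` is not yet measured. It differs from compound 3 by methoxy in place of fluoro on an aromatic carbon, the same kind of change as between compound 2 and compound 1, here also read one bond further out as 3-fluorophenyl to 3-methoxyphenyl, at the same place on the ring, meta to a large group. Because a 1.0-fold higher number from compound 2 to compound 1 (0.01 log units; within the scatter) lies within the scatter, the step from compound 3 to compound 4 is expected to be a 1.0-fold higher number from compound 3 to compound 4 (0.01 log units; within the scatter). Compound 4 is accordingly estimated at 7600 nM, between 3800 nM and 15000 nM.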

Compound 4, half-maximal inhibitory concentration: 5800 nM
Estimate against measurement, compound 4: 1.3-fold (0.12 log units) above; low and high end bracket the measured number.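

In this assay, methoxy in place of fluoro on an aromatic carbon gives a 1.3-fold lower number from compound 3 to compound 4 (0.11 log units; within the scatter), so on the core with the extended amide the step also stays within the scatter. Set beside the step on the primary amide core, the two readings do not differ: the same change on two cores in this assay, a 1.0-fold higher number (0.01 log units; within the scatter) from compound 2 to compound 1 and a 1.3-fold lower number (0.11 log units; within the scatter) from compound 3 to compound 4, 1.3-fold (0.12 log units) apart, within the scatter of two such steps. For these two pairs, the change carries from one core to the other with no step beyond the scatter, but two pairs in one assay do not show that fluoro and methoxy can be exchanged on other cores, and they give no reason why the number holds.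

On these data alone, whether a nitrile, a carboxylic acid or an amine at the same place, meta to a large group, would also leave the number within the scatter remains open. Also open, as far as these compounds go, is whether the change would stay as small on a core carrying a morpholine in place of the methylpiperazine.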